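A few compounds are considered here, and "the series" means these few. Any claim that something is new, unique, unknown or untested is made for them only; others in the source may bear on it.

Compound 1, `CC1=NC(C)=C([N+](=O)[O-])C(c2cccnc2)/C1=C(\O)OC1CCCCC1`: 2760 nM
Compound 2, `CC1=NC(C)=C([N+](=O)[O-])C(c2ccncc2)/C1=C(\O)OC(C)(C)C`: 2820 nM
Compound 3, `CC1=NC(C)=C([N+](=O)[O-])C(c2ccccn2)/C1=C(\O)OCC(C)C`: 9100 nM

All three share one core and were tested in a functional assay (cardiac atrium) for agonist activity, with Cavia porcellus as the target; on this read-out lower numbers stand for an effect already at smaller amounts and higher numbers for an effect only at larger amounts of compound. Compound 3 gives 9100 nM, the highest of the three numbers; compound 2 gives 2820 nM and compound 1 gives 2760 nM, both differences being beyond the usual scatter, so compound 3 needs the largest amount of the three.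

The next compound, compound 4, `CC1=NC(C)=C([N+](=O)[O-])C(c2ccccn2)/C1=C(\O)OC(C)(C)C`, keeps everything of compound 3 except one group: tert-butyl in place of isobutyl on an oxygen on an unsaturated carbon. Seen one bond further out, this is isobutoxy turning into tert-butoxy.

Among the measured compounds shown here, no measured pair in this set isolates that change, so its size is not known from the data. Compound 2 carries the tert-butyl group and gives 2820 nM, but its ring is attached differently, so it does not settle the question. The step from compound 3 to compound 4 is expected to be modest, toward a lower number, and it may well stay within the scatter: a 1.4-fold lower number from compound 3 to compound 4 (0.15 log units; within the scatter). Compound 4 is therefore estimated at 6500 nM, with a range from 2200 nM to 19000 nM.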

Compound 4, half-maximal effective concentration: 1810000 nM
For compound 4 the middle estimate is 280-fold (2.44 log units) below the measured one, outside the stated range (above it).
By their numbers in this assay, from the lowest: compounds 1 and 2 (each within the scatter of the next); then compound 3; then compound 4.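

This position turns out to be very sensitive to how the atoms are joined: isobutyl and tert-butyl have the same atoms, yet tert-butyl in place of isobutyl on the oxygen gives a 200-fold higher number from compound 3 to compound 4 (2.30 log units; beyond the scatter), and a higher number here means far more compound is needed for the effect. Tert-butyl alone does not account for this picture, as pyridin-2-yl in place of pyridin-4-yl gives a 640-fold higher number from compound 2 to compound 4 (2.81 log units; beyond the scatter), so compound 4 stands far from both of its single-change neighbours and the effect of each change depends on the other group present. Nothing available here explains this jump.

Going by these compounds, it remains open whether an ethyl group or a straight n-butyl chain on the same oxygen would behave more like isobutyl or like tert-butyl. On these data alone, whether isobutyl would give a similar number alongside pyridin-4-yl is also open.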